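The source may hold more compounds than are shown below. What is called first, only, known or untested is meant among the compounds shown, and "the series" means these compounds.

Measured in a functional assay on HepG2 cells (Homo sapiens) for inhibition, read by MTT assay, with a stated time of 48 h; on this read-out lower numbers stand for stronger inhibition and higher numbers for weaker inhibition:
- Compound 1 `COc1cc(OC)c(OC)cc1/C=C/C(=O)c1cc(OC)c(OC)c(OC)c1`: 16100 nM
- Compound 2 `COc1cc(/C=C/C(=O)c2cc(OC)c(OC)c(OC)c2)ccc1O`: > 100000 nM, a limit of the assay and not a number
- Compound 3 `COc1cc(C(=O)/C=C/c2ccc(O)c(O)c2)cc(OC)c1OC`: 14900 nM

Compound 3 and compound 1 lie within the scatter of each other. Compound 4 `COc1cc(C(=O)/C=C/c2ccc(C)cc2)cc(OC)c1OC` has 4-methylphenyl in place of 3,4-dihydroxyphenyl on a double-bonded chain carbon bound to a double-bonded chain carbon. Among the compounds with values here, the one measured step that bears on this is an at least 6.7-fold lower number from compound 2 to compound 3 (0.82 log units; beyond the scatter), with hydrogen in place of methyl on an oxygen on an aromatic ring. Compound 1 goes against reading that step as a rule: it has methyl on every aromatic-ring oxygen and still gives 16100 nM. So a moderate rise is expected in this assay, and the estimated change is a 2.0-fold higher number from compound 3 to compound 4 (0.30 log units; within the scatter). Compound 4 is estimated at 30000 nM, with an expected range of 9000 nM to 100000 nM.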

Compound 4, half-maximal inhibitory concentration: 52000 nM
Compound 4: middle estimate off by 1.7-fold (0.24 log units), on the low side; low and high end bracket the measured number.
By their numbers in this assay, from the lowest: compounds 3 and 1 (each within the scatter of the next); then compound 4. At a limit, above all of these: compound 2.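

In this assay, replacing 3,4-dihydroxyphenyl with 4-methylphenyl on the double-bonded chain carbon gives a 3.5-fold higher number from compound 3 to compound 4 (0.54 log units; beyond the scatter). Within the data shown here, this is the first measured change to this aryl group itself, and it shows that the group affects the read-out, though only modestly. Nothing measured here explains the rise. The compounds shown do not separate the loss of the two hydroxyls from the gain of the methyl, and they leave open how an amine or a carboxylic acid on this ring would behave.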